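Two Chloromethylbenzyl Purines and an Amino Analogue

This account rests on a few compounds, and the source may have more. Where it says the series, first, only, none or still open, it means among the compounds named here.

Measured compounds:
compound 1 `ClCc1ccccc1Cn1cnc2c(Cl)nc(Cl)nc21`: 6160 nM
compound 2 `ClCc1cccc(Cn2cnc3c(Cl)nc(Cl)nc32)c1`: 6160 nM

In a functional assay on HCC 2998 cells (Homo sapiens) for cytotoxicity, read by sulforhodamine B assay, with a stated time of 48 h (on this read-out higher numbers stand for lower toxicity in this test and lower numbers for higher toxicity in this test), compound 1 gives 6160 nM. Compound 2, which differs from it only in the placement of the chloromethyl group on the benzyl ring, gives 6160 nM in this assay; the two values agree at the digits shown and lie within the scatter of each other, so compound 1 stands level with its one neighbour.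

Compound 3 `Nc1nc(Cl)c2ncn(Cc3ccccc3CCl)c2n1` has not been measured in this assay. It differs from compound 1 by amino in place of chloro on an aromatic carbon. Going by the values given here, no measured pair shows what this exchange does in this assay. Compound 3 is expected to give 9000 nM, within 3000 nM to 30000 nM. The expected step of a 1.5-fold higher number from compound 1 to compound 3 (0.16 log units; within the scatter) is estimated as small, toward lower toxicity, and may not exceed the scatter.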

Compound 3, concentration lethal to 50% of the cells: 26300 nM
Compound 3: the middle estimate sits 2.9-fold (0.47 log units) below what was measured; the measured number falls inside the stated range.
By their numbers in this assay, from the lowest: compounds 1 and 2 (each within the scatter of the next); then compound 3.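

In this assay, putting amino in place of chloro on the aromatic carbon between two ring nitrogen atoms brings a 4.3-fold higher number from compound 1 to compound 3 (0.63 log units; beyond the scatter), a move toward lower toxicity in this test. Going by these compounds alone, compound 1 and compound 2 had stood level when only the placement of the chloromethyl group differed, so this position on the core is the first place here where a single exchange moves the number beyond the scatter. No available evidence accounts for the size or direction of this step.

From the compounds shown here alone, it remains open whether this step is particular to amino or would also appear with a methoxy or dimethylamino group at this position. Also open, going by these compounds, is whether the same exchange would bring a similar step on compound 2, or at the remaining chloro position of the core.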